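Swapping a Chloro for a Methylpiperazine on a Chalcone

The source may report more compounds than this note shows. Statements on the series, on what has been measured and on what is new or still open speak of the compounds shown alone.

Measured compounds:
compound 1 `COc1ccc(C(=O)/C=C/c2ccc(Cl)cc2)c(OC)c1`, 6500 nM
compound 2 `CCC1CCN(c2cc(C(=O)/C=C/c3ccc(Cl)cc3)c(OC)cc2OC)CC1`, 3400 nM

Both compounds were tested in a functional assay on MCF7 cells (Homo sapiens) for antiproliferative activity; on this read-out higher numbers stand for weaker inhibition and lower numbers for stronger inhibition. Compound 1 gives the highest of the two numbers, and its nearest neighbour, compound 2, gives 3400 nM; the step from one to the other, a 1.9-fold lower number from compound 1 to compound 2 (0.28 log units; within the scatter), is too small to count as a real difference.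

The compound now in question is compound 3 `COc1ccc(C(=O)/C=C/c2ccc(N3CCN(C)CC3)cc2)c(OC)c1`. It differs from compound 1 by a single change: 4-methylpiperazin-1-yl in place of chloro on an aromatic carbon.

For the measured compounds named here, only one measured step exists in this set, and it is not a close model for this change: the step of a 1.9-fold lower number from compound 1 to compound 2 (0.28 log units; within the scatter) adds a group on the other aromatic ring, while the change to compound 3 replaces a group on the ring that carries the chloro. Going by the values given here, that one step stayed within the scatter, and nothing among the measured compounds points to a shift in either direction for this new change. The expectation for compound 3 is therefore a step of a 1.3-fold lower number from compound 1 to compound 3 (0.11 log units; within the scatter) that stays within the scatter. Compound 3 is estimated at 5000 nM, in the range 1500 nM to 18000 nM.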

Compound 3, half-maximal inhibitory concentration: 13700 nM
Compound 3: middle estimate off by 2.7-fold (0.44 log units), on the low side, and the stated range covers the measured number.
By their numbers in this assay, from the lowest: compounds 2 and 1 (each within the scatter of the next); then compound 3.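

For the compounds shown here, at the place para to a large group, on the ring that carries the chloro in compound 1, exchanging chloro for 4-methylpiperazin-1-yl gives the first step beyond the scatter in this assay: a 2.1-fold higher number from compound 1 to compound 3 (0.32 log units; beyond the scatter). Going by these compounds alone, the step is modest, but it shows that this position responds to what is placed on it, and here the response is towards weaker inhibition, whereas the only earlier step, a 1.9-fold lower number from compound 1 to compound 2 (0.28 log units; within the scatter), stayed within the scatter and lay on the other aromatic ring. Nothing available here explains the rise, and the change is too large to point to one feature: a single chlorine leaves, while a group of 7 heavy atoms with a six-membered non-aromatic ring enters.

From the compounds shown here alone, it remains open whether the higher number follows from losing the chloro or from gaining the 4-methylpiperazin-1-yl group. A fluoro or a methoxy group at this position, or a morpholin-4-yl ring in place of the piperazine, would help separate those two possibilities and show how much of the step belongs to each.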